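Replacing a benzyl ether by a fluorophenyl ether

A few compounds are considered here, and "the series" means these few. Any claim that something is new, unique, unknown or untested is made for them only; others in the source may bear on it.

Measured compounds:
- compound 1, `O=C(Nc1cccc(C(F)(F)F)c1)N[C@H]1CC[C@H](Oc2cccc(C(F)(F)F)c2)CC1`, gives 1300 nM in a functional assay on CRL2813 cells (Homo sapiens) for cytotoxicity, read by sulforhodamine B assay, with a stated time of 5 days; on this read-out lower numbers stand for stronger inhibition and higher numbers for weaker inhibition
- compound 2, `O=C(Nc1cccc(C(F)(F)F)c1)N[C@H]1CC[C@H](OCc2ccc(F)cc2)CC1`, gives 2650 nM in this assay

Compound 2 has the highest of the two numbers, and its nearest neighbour is compound 1, with a 2.0-fold higher number from compound 1 to compound 2 (0.31 log units; beyond the scatter) separating them. In that step, the aromatic ring attached directly to the oxygen was swapped for a 4-fluorobenzyl group, and the number rose modestly.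

Compound 3, `O=C(Nc1cccc(C(F)(F)F)c1)N[C@H]1CC[C@H](Oc2ccccc2F)CC1`, is not yet measured. It differs from compound 2 by 2-fluorophenyl in place of 4-fluorobenzyl on an oxygen on a saturated carbon. This change returns to an aromatic ring attached directly to the oxygen, as in compound 1, though the ring now carries a fluorine rather than a trifluoromethyl group. Among the measured compounds shown here, the only step that bears on it is a 2.0-fold higher number from compound 1 to compound 2 (0.31 log units; beyond the scatter), which ran in the opposite direction to the present change. A modest step downward in this assay is therefore expected, roughly undoing that earlier rise, while the different substituent on the ring leaves room for deviation. For compound 3 the estimate is 1500 nM, within 600 nM to 4000 nM, corresponding to an expected 1.8-fold lower number from compound 2 to compound 3 (0.25 log units; within the scatter).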

Compound 3, half-maximal inhibitory concentration: 2450 nM
Estimate against measurement, compound 3: 1.6-fold (0.21 log units) below; measured number inside the range.
By their numbers in this assay, from the lowest: compounds 1, 3 and 2 (each within the scatter of the next, the first and the last beyond it).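

In this assay, going back to a ring attached directly to the oxygen does not by itself separate the new compound from the benzyl ether: 2-fluorophenyl in place of 4-fluorobenzyl gives a 1.1-fold lower number from compound 2 to compound 3 (0.03 log units; within the scatter), a step that cannot be told from repeat-measurement noise. Compared with the other aryl ether, 2-fluorophenyl in place of 3-(trifluoromethyl)phenyl gives a 1.9-fold higher number from compound 1 to compound 3 (0.28 log units; within the scatter), which also lies within the scatter, so compound 3 cannot be ranked against either neighbour, even though a 2.0-fold higher number from compound 1 to compound 2 (0.31 log units; beyond the scatter) lies just beyond it. At this place on the shared core, the three groups therefore give numbers that sit close together, and no measurement available here offers an explanation for them.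

Compound 2 and compound 3 differ both in how the ring is attached and in where the fluorine sits, so the two contributions cannot be separated, and a 4-fluorophenyl group would be needed to do that. From the compounds shown here alone, it also remains open how this position responds to groups of a different kind, such as a longer chain like 2-phenylethyl, or a ring carrying an amine or a carboxylic acid.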